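The source may report more compounds than this note shows. Statements on the series, on what has been measured and on what is new or still open speak of the compounds shown alone.

Measured so far:
compound 1, `CS(=O)(=O)c1ccc2c(c1)nc(-c1cccnc1)n2C1CC1`: > 10000 nM (a limit)
compound 2, `N#Cc1cc2c(cc1F)nc(-c1cccnc1)n2C1CC1`: 117 nM
compound 3, `CC(C)(C)n1c(-c2cccnc2)nc2ccc(F)cc21`: > 10000 nM (a limit)

In an assay on V79 cells for inhibition of cytochrome P450 11B1, mitochondrial (Homo sapiens), read by HTRF, with a stated time of 1 h (a lower number here means a stronger inhibitor, a higher number a weaker inhibitor), compound 3 gives only > 10000 nM, which is a limit of the assay and not a number. Compound 1 likewise stops at > 10000 nM, again a limit. Both of these compounds therefore sit at the limit of > 10000 nM in this assay, at which 2 of the 3 values shown sit. Among the measured compounds shown here, compound 2 is the one member with a number, 117 nM. Compound 3 thus stands at the weak end of what is shown, and no measured step joins it to either of the other two compounds.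

Compound 4, `Fc1ccc2nc(-c3cccnc3)n(C3CCC3)c2c1`, differs from compound 3 in one place: cyclobutyl in place of tert-butyl on an aromatic nitrogen. For the measured compounds named here, no step between measured compounds covers this change, so any expectation rests on the values alone. Compound 3 gives only a limit. Compound 2, which carries a small carbocycle on the same ring nitrogen, gives 117 nM, so a gain for compound 4 in this assay is expected, though of uncertain size. Compound 4 is expected to reach about 3000 nM, within 500 nM to 15000 nM. The expected step from compound 3 to compound 4 is an at least 3.3-fold lower number from compound 3 to compound 4 (0.52 log units; beyond the scatter). A further limit for compound 4 cannot be excluded.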

Compound 4, half-maximal inhibitory concentration: > 10000 nM
Compound 4: only a limit was reported; the forecaster's own chance of this, stated with the estimate: 35%; middle value at least 3.3-fold (0.52 log units) from the limit.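

Compound 3 and compound 4 both stop at a limit in this assay, so the change from tert-butyl to cyclobutyl on the aromatic nitrogen gives no readable step: the limit of > 10000 nM in this assay, at which 3 of the 4 values shown sit.

The compounds shown leave open how far either compound lies beyond that limit, and whether this change alters inhibition at all.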